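A few compounds are considered here, and "the series" means these few. Any claim that something is new, unique, unknown or untested is made for them only; others in the source may bear on it.

Working notes on the series. Three compounds have been run in a functional assay on NCI-H23 cells (Homo sapiens) for cytotoxicity, read by sulforhodamine B assay, with a stated time of 48 h; a higher number here means a weaker inhibitor of growth, a lower number a stronger inhibitor of growth. Compound 1 `ClCc1ccc(Cn2cnc3c(Cl)ncnc32)cc1` gives 2450 nM. Compound 2 `ClCc1cccc(Cn2cnc3ncnc(Cl)c32)c1` has the same atoms as compound 1 joined differently, and in this assay compound 2 gives 3380 nM; the difference between the two cores is not broken down here, and the two values lie within the scatter of each other, so no order is drawn between them. Compound 3 `ClCc1ccc(Cn2cnc3c(Cl)nc(Cl)nc32)cc1` gives 23400 nM in this assay, a value well apart from those of both compound 1 and compound 2. Going by the values given here, the one counted step among the measured compounds is chloro in place of hydrogen on an aromatic carbon, and it produced a 9.6-fold higher number from compound 1 to compound 3 (0.98 log units; beyond the scatter).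

Compound 4 `ClCc1cccc(Cn2cnc3nc(Cl)nc(Cl)c32)c1` remains to be measured. It is reached from compound 2 by chloro in place of hydrogen on an aromatic carbon; the place description is the same word for word as for the change from compound 1 to compound 3, so this is the same change applied to the core of compound 2. On that single precedent, the expectation for compound 4 in this assay is 32000 nM, between 12000 nM and 85000 nM. That estimate means an expected step of a 9.5-fold higher number from compound 2 to compound 4 (0.98 log units; beyond the scatter), to be set beside a 9.6-fold higher number from compound 1 to compound 3 (0.98 log units; beyond the scatter). Among the compounds with values here, it rests on compound 2 at 3380 nM and on the one prior instance of the change; with only one precedent the range is kept wide.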

Compound 4, concentration for total growth inhibition: 30900 nM
The estimate for compound 4 lay 1.0-fold (0.02 log units) above the measured number; low and high end bracket the measured number.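

In this assay, chloro in place of hydrogen on an aromatic carbon gives a 9.1-fold higher number from compound 2 to compound 4 (0.96 log units; beyond the scatter), and the size of this step does not differ from that of the earlier step on the other core: the same change on two cores in this assay, a 9.6-fold higher number (0.98 log units; beyond the scatter) from compound 1 to compound 3 and a 9.1-fold higher number (0.96 log units; beyond the scatter) from compound 2 to compound 4, 1.0-fold (0.02 log units) apart, within the scatter of two such steps

Within these four compounds, the change therefore carries from the core of compound 1 to the core of compound 2 with its direction and size intact, both pairs moving towards weaker inhibition of growth, and neither pair goes against this. It does not show that the step would hold on any further core, since it rests on two pairs in a single cell line with a single read-out, and the numbers give no account of why the chloro group has this effect.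

On these data alone, what stays open is whether the step is specific to chloro, as an amine, a methoxy group or a fluoro group on the same aromatic carbon, between two ring nitrogen atoms, would test that directly. Also open, as far as these compounds go, is whether the step keeps its size when the chloromethyl group on the benzyl ring gives way to a hydroxymethyl group or a longer chain.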